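Stability of Compound 4 Judged from Three Close Analogues

The compounds below may be only part of what the source reports. "The series", "measured", "known", "first", "only" and "open" are said of these compounds alone.

Compound 1 `CC(C)C(c1ccc(-c2ccc3cccc(F)c3c2)[nH]c1=O)N1CCCCC1=O` gives 0.183 h in an ADME assay on microsomes from liver (Homo sapiens) for metabolic stability; a lower number here means that the compound disappears faster, a higher number that the compound lasts longer.
Compound 2 `CC(C)C(Nc1nccs1)c1ccc(-c2ccc3cccc(F)c3c2)[nH]c1=O` gives 0.17 h.
Compound 3 `CC(C)C(Cc1ncc[nH]1)c1ccc(-c2ccc3cccc(F)c3c2)[nH]c1=O` gives 0.106 h.

Compound 3 holds the lowest of these three numbers, yet its nearest neighbour, compound 2, sits only a 1.6-fold lower number from compound 2 to compound 3 (0.21 log units; within the scatter) away, and the furthest, compound 1, only a 1.7-fold lower number from compound 1 to compound 3 (0.24 log units; within the scatter); both gaps fall within the scatter, so no order among the three can be claimed. The remaining step is also within the scatter: a 1.1-fold lower number from compound 1 to compound 2 (0.03 log units; within the scatter).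

Compound 4 `CC(C)C(c1ccc(-c2ccc3cccc(F)c3c2)[nH]c1=O)N1CCNC1=O` has not yet been measured in this assay. It differs from compound 3 in one place:
2-oxoimidazolidin-1-yl in place of (1H-imidazol-2-yl)methyl on a saturated chain carbon bound to an aromatic carbon and a saturated chain carbon

Within the data shown here, no measured step covers this exact exchange. The step that comes closest is a 1.7-fold lower number from compound 1 to compound 3 (0.24 log units; within the scatter), which swaps a 2-oxopiperidin-1-yl for the (1H-imidazol-2-yl)methyl at the same place, and compound 4 brings in a 2-oxoimidazolidin-1-yl at that place. Since every step among compounds 1, 2 and 3 stayed within the scatter, the expectation for compound 4 in this assay is a step no larger than the scatter, leaning slightly upward: a 1.4-fold higher number from compound 3 to compound 4 (0.15 log units; within the scatter). Compound 4 is therefore estimated at 0.15 h, with a range from 0.08 h to 0.3 h.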

Compound 4, half-life: 1.03 h
Beside the measured number, compound 4's estimate is 6.9-fold (0.84 log units) below it, outside the stated range (above it).
By their numbers in this assay, from the lowest: compounds 3, 2 and 1 (each within the scatter of the next); then compound 4.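

In this assay, the steps among the first three compounds stayed within the scatter, so the position on a saturated chain carbon bound to an aromatic carbon and a saturated chain carbon had shown no effect, but the 2-oxoimidazolidin-1-yl group changes that, with a 9.7-fold higher number from compound 3 to compound 4 (0.99 log units; beyond the scatter), a 6.1-fold higher number from compound 2 to compound 4 (0.78 log units; beyond the scatter) and a 5.6-fold higher number from compound 1 to compound 4 (0.75 log units; beyond the scatter). The number at this position therefore can respond to the group placed there, and the response is not tied to a ring carbonyl alone: compound 1 also carries one, in its 2-oxopiperidin-1-yl group, yet it lies within the scatter of compound 2 and compound 3, and well short of compound 4. Nothing at hand accounts for this difference.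

The compounds shown leave open which feature of the 2-oxoimidazolidin-1-yl group matters, since a 2-oxopyrrolidin-1-yl ring, a 2-oxooxazolidin-3-yl ring or an open-chain urea at the same place would separate the ring size from the ring nitrogen bearing its hydrogen. They also leave open whether the same exchange would hold on a core other than the shared one, or with a chain other than the one on this carbon.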